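Pyridin-2-yl in place of ethyl on compound 2

A few compounds are considered here, and "the series" means these few. Any claim that something is new, unique, unknown or untested is made for them only; others in the source may bear on it.

Compound 2 `CCN1CCN(c2cccc3c2C[C@H](CN(C)[C@H]2CCCc4cccnc42)NC3)CC1` was examined in a functional assay on CCRF-CEM cells for agonist activity at C-X-C chemokine receptor type 4 (Homo sapiens), read by calcium flux, with a stated time of 25 min; on this read-out higher numbers stand for an effect only at larger amounts of compound and lower numbers for an effect already at smaller amounts. In this assay compound 2 gives > 30000 nM, which is a limit of the assay and not a number. Compound 1 `CN(C[C@H]1Cc2c(cccc2N2CCN(Cc3ccccn3)CC2)CN1)[C@H]1CCCc2cccnc21` carries pyridin-2-yl where compound 2 carries methyl on a saturated chain carbon bound to the ring amine nitrogen. In this assay compound 1 gives > 30000 nM, again a limit rather than a number. The step that the two limits leave unreadable from compound 1 to compound 2 consequently cannot be read. Every measured value in this set sits at the limit of > 30000 nM in this assay, at which 2 of the 2 values shown sit. Compound 3 `CN(C[C@H]1Cc2c(cccc2N2CCN(c3ccccn3)CC2)CN1)[C@H]1CCCc2cccnc21` differs from compound 2 in one place: pyridin-2-yl in place of ethyl on an amine nitrogen in a ring. Among the compounds with values here, the only measured step that touches this part of the molecule, a step that the two limits leave unreadable from compound 1 to compound 2, is unreadable, so no step size can be carried over to compound 3. Given that all measured values sit at the limit of > 30000 nM in this assay, at which 2 of the 2 values shown sit, compound 3 is expected to remain near that limit, and the step of a number no higher from compound 2 to compound 3 (the limit leaves the size open) is estimated as no change beyond the scatter. Compound 3 is accordingly estimated at 30000 nM in this assay, within a range from 6000 nM to 150000 nM.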

Compound 3, half-maximal effective concentration: > 30000 nM
Compound 3: only a limit was reported; the forecaster's own chance of this, stated with the estimate: 75%; the middle value sits exactly at the limit.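

In this assay compound 3 gives > 30000 nM which is a limit of the assay and not a number. The steps joining compound 1, compound 2 and compound 3 therefore cannot be read. The compounds shown leave open whether any change on this ring amine nitrogen alters the read-out at all: the limit of > 30000 nM in this assay, at which 3 of the 3 values shown sit.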